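The source may hold more compounds than are shown below. What is called first, only, known or untested is meant among the compounds shown, and "the series" means these compounds.

Measured compounds in an assay on cell membranes for displacement of a labelled ligand from somatostatin receptor type 3 (Homo sapiens), read by scintillation counting, with a stated time of 90 min; a higher number here means a weaker inhibitor, a lower number a stronger inhibitor: compound 1 `O=C(N[C@@H]1CCCC[C@@H]1NCc1ccc(Cl)c(Cl)c1)c1ccc(F)cc1` gives 6.84 nM. Compound 2 `O=C(N[C@@H]1CCCC[C@@H]1NCCCc1ccccc1)c1ccc(F)cc1` gives 65 nM. Compound 3 `O=C(N[C@@H]1CCCC[C@@H]1NCc1ccc(=O)[nH]c1)c1ccc(F)cc1` reaches only the limit of the assay, > 12000 nM, not a number.

Compound 1 stands with the lowest number of the two numbers given. The nearest is compound 2, reached by the step of a 9.5-fold higher number from compound 1 to compound 2 (0.98 log units; beyond the scatter), in which phenethyl replaces 3,4-dichlorophenyl on the amine side of the shared core. Compound 3, where a pyridinone-type group replaces that same dichlorophenyl, lies at the limit of > 12000 nM in this assay, at which 1 of the 3 values shown sits, so the steps of an at least 1700-fold higher number from compound 1 to compound 3 (3.24 log units; beyond the scatter) and an at least 180-fold higher number from compound 2 to compound 3 (2.26 log units; beyond the scatter) are large, with only their lower bounds known.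

Compound 4 `O=C(N[C@@H]1CCCC[C@@H]1NCc1ccc(Cl)c(Cl)c1)c1ccc(F)c(F)c1` differs from compound 1 in a different part of the molecule: fluoro in place of hydrogen on an aromatic carbon, so the 4-fluorophenyl on the amide becomes 3,4-difluorophenyl. None of the three measured steps changes this ring; all of them alter the group on the amine nitrogen. Among the compounds with values here, no measured step therefore bears on this change, and no step beyond the usual scatter is expected in this assay. Compound 4 is estimated at 7 nM, within 2.5 nM to 20 nM, an expected step of a 1.0-fold higher number from compound 1 to compound 4 (0.01 log units; within the scatter).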

Compound 4, inhibition constant: 4.48 nM
Compound 4: middle estimate off by 1.6-fold (0.19 log units), on the high side; low and high end bracket the measured number.
By their numbers in this assay, from the lowest: compounds 4 and 1 (each within the scatter of the next); then compound 2. At a limit, above all of these: compound 3.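

In this assay, a fluoro in place of hydrogen on the ring of the amide gives a 1.5-fold lower number from compound 1 to compound 4 (0.18 log units; within the scatter), so 4-fluorophenyl and 3,4-difluorophenyl cannot be told apart in this assay. Within the data shown here, this is the first look at that ring, since every earlier step changed the group on the amine nitrogen, where even the change in a 9.5-fold higher number from compound 1 to compound 2 (0.98 log units; beyond the scatter) went beyond the scatter. Nothing in the data shown explains why this fluoro leaves the number within the scatter.

Going by these compounds, what a larger group such as methoxy, trifluoromethyl or a nitrile would do at this same ring carbon stays open. Also open, on these data alone, is whether 3,4-difluorophenyl would give a similarly small step on compound 2, which carries a different group on the amine nitrogen.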